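The compounds below may be only part of what the source reports. "The series", "measured", "known", "first", "only" and "open" are said of these compounds alone.

Three compounds have so far been measured in a functional assay on MCF7 cells (Homo sapiens) for cytotoxicity, read by MTT assay, with a stated time of 24 h, tested at 0.64 ug/mL; a higher number here means a stronger effect of the compound at the concentration tested, a lower number a weaker effect:

compound 1, `Cn1c(-c2ccc(NC(=O)CCl)cc2)nc(-c2ccccc2)c1-c1ccccc1`, gives 3.4%;
compound 2, `Cn1c(-c2ccc(NC(=O)CSc3nc4ccccc4o3)cc2)nc(-c2ccccc2)c1-c1ccccc1`, gives 18.7%;
compound 3, `CN(C)/C=C/N1CCN(CC(=O)Nc2ccc(-c3nc(-c4ccccc4)c(-c4ccccc4)n3C)cc2)CC1`, gives 1.2%.

Compound 3 stands lowest of the three. Its nearest neighbour is compound 1, with a number 2.2 percentage points lower from compound 1 to compound 3 (within the scatter); its furthest is compound 2, with a number 17.5 percentage points lower from compound 2 to compound 3 (beyond the scatter).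

Compound 4, `Cn1c(-c2ccc(NC(=O)CN3CCN(c4ccccc4)CC3)cc2)nc(-c2ccccc2)c1-c1ccccc1`, has not yet been measured. It differs from compound 3 by phenyl in place of 2-(dimethylamino)ethenyl on an amine nitrogen in a ring. Within the data shown here, no measured step exchanges the group on the ring nitrogen of the six-membered non-aromatic ring; the steps that come closest, a number 2.2 percentage points lower from compound 1 to compound 3 (within the scatter) and a number 17.5 percentage points lower from compound 2 to compound 3 (beyond the scatter), exchange the whole group at the chain carbon bound to the carbonyl carbon, and even the larger of these was only modest. Since all three measured values sit close together at the low end, the account expects at most a small step in this assay from compound 3 to compound 4, and quite possibly none beyond the scatter. The expected step is a number 3.8 percentage points higher from compound 3 to compound 4 (within the scatter). Compound 4 is therefore estimated at 5%, with a range from 0% to 18%.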

Compound 4, a percentage reported as activity, at one concentration (the size of the read-out at that concentration, not a potency): 12.1%
Beside the measured number, compound 4's estimate is 7.1 percentage points below it, and the stated range covers the measured number.
By their numbers in this assay, from the lowest: compounds 3, 1, 4 and 2 (each within the scatter of the next, the first and the last beyond it).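

With phenyl in place of 2-(dimethylamino)ethenyl on an amine nitrogen in a ring, the compounds show a number 10.9 percentage points higher from compound 3 to compound 4 (beyond the scatter), the first measured sign that the group on this ring nitrogen alone can move the read-out, though only modestly. Taken whole, 4-phenylpiperazin-1-yl gives a number 8.7 percentage points higher from compound 1 to compound 4 (within the scatter) in place of chloro and a number 6.6 percentage points lower from compound 2 to compound 4 (within the scatter) in place of (1,3-benzoxazol-2-yl)sulfanyl, so compound 4 cannot be separated from either compound, even though the step between those two lies beyond the scatter. Nothing available explains the step from the 2-(dimethylamino)ethenyl group to phenyl.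

The compounds shown leave open what a methyl or a benzyl group on this ring nitrogen would give. They also leave open whether the ring nitrogen needs any group at all, as a plain hydrogen there would test.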